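A few compounds are considered here, and "the series" means these few. Any claim that something is new, unique, unknown or untested is made for them only; others in the source may bear on it.

Measured so far:
Compound 1, `CCCc1nc(-c2ccccc2)c(CNCCN2CCN(c3ccccc3F)CC2)o1`: 46.5%
Compound 2, `CCCc1nc(-c2ccccc2)c(CNCCCN2CCN(c3cccc(C(F)(F)F)c3)CC2)o1`: 51.6%

Both numbers come from an assay on HEK293 cells for inhibition of Voltage-dependent T-type calcium channel subunit alpha-1G (Homo sapiens), read by fluorescence, tested at 10 uM; a lower number here means less inhibition, a higher number more inhibition at the concentration tested (going by the name of the read-out). For the measured compounds named here, compound 2 shows one of only two numbers, and its gap to compound 1 lies within the usual scatter of such measurements, so the two compounds cannot be told apart on this evidence; the number of neither can be called higher or lower than that of the other.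

Compound 3, `CCCc1nc(-c2ccccc2)c(CNCCCN2CCN(c3ccc(C(F)(F)F)cc3)CC2)o1`, has the same atoms as compound 2 joined differently: 4-(trifluoromethyl)phenyl in place of 3-(trifluoromethyl)phenyl on an amine nitrogen in a ring. Going by the values given here, no pair of measured compounds differs in just this one way, so there is no measured step to lean on. With the two measured numbers sitting so close together, the step from compound 2 to compound 3 is expected to stay within the scatter, with no clear direction, an expected step of a number 1.6 percentage points lower from compound 2 to compound 3 (within the scatter).

Compound 3 is therefore estimated to give 50% in this assay, with a range from 30% to 70%.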

Compound 3, a percentage reported as inhibition, at one concentration (the size of the read-out at that concentration, not a potency): 51.6%
Estimate against measurement, compound 3: 1.6 percentage points below; measured number inside the range.
By their numbers in this assay, from the lowest: compounds 1, 2 and 3 (each within the scatter of the next).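

In this assay, for the compounds shown here, putting 4-(trifluoromethyl)phenyl in place of 3-(trifluoromethyl)phenyl on the ring amine nitrogen gives no change at the digits printed from compound 2 to compound 3 (within the scatter) as the first single-place step. For this one pair, then, the change of attachment point of the trifluoromethyl group on the phenyl ring leaves the percentage inhibition unresolved from no effect, although a reading at one concentration is not a potency and could hide a difference in potency. Nothing available here offers an explanation for this result.

Compound 1 differs from compound 2 and compound 3 in more than one place, so the contributions of the chain and the aryl group remain unseparated. Also open, from the compounds shown here alone, is whether a nitrile or a methoxy group in place of trifluoromethyl, or a longer chain to the ring nitrogen, would shift the inhibition beyond the scatter.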